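A few compounds are considered here, and "the series" means these few. Any claim that something is new, unique, unknown or untested is made for them only; others in the source may bear on it.

Measured compounds:
Compound 1 `CNC(=O)[C@@]12C[C@@H]1[C@@H](n1cnc3c(NC)nc(C#Cc4nccs4)nc31)[C@H](O)[C@@H]2O` gives 2.1 nM in an assay on CHO cells for displacement of a labelled ligand from adenosine receptor A3 (Homo sapiens), read by scintillation counting, with a stated time of 60 min; a higher number here means a weaker inhibitor, a lower number a stronger inhibitor.
Compound 2 `CNC(=O)[C@@]12C[C@@H]1[C@@H](n1cnc3c(NC)nc(C#CC4CC4)nc31)[C@H](O)[C@@H]2O` gives 1.15 nM in this assay.

Of the two numbers at hand, compound 2 has the lower one, and its nearest neighbour is compound 1; the difference, a 1.8-fold lower number from compound 1 to compound 2 (0.26 log units; within the scatter), is within the scatter, so the two compounds cannot be told apart on this evidence. Compound 3 `CNC(=O)[C@@]12C[C@@H]1[C@@H](n1cnc3c(NC)nc(C#CC4CCCCC4)nc31)[C@H](O)[C@@H]2O` has not been measured. It differs from compound 2 in one place: cyclohexyl in place of cyclopropyl on a triple-bonded carbon. Among the measured compounds shown here, the one measured step that speaks to this position is the exchange of a 1,3-thiazol-2-yl for a cyclopropyl on the triple-bonded carbon, which left the number essentially where it was. Nothing measured here tests a change in the size of a saturated ring at that place, so the expectation rests on the observation that two rather different groups on the same carbon gave similar numbers. The step from compound 2 to compound 3 is therefore expected to be small, about a 1.7-fold higher number from compound 2 to compound 3 (0.24 log units; within the scatter), and not clearly beyond the scatter. Compound 3 is accordingly estimated at 2 nM, with a range from 0.5 nM to 8 nM.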

Compound 3, inhibition constant: 1.68 nM
The estimate for compound 3 lay 1.2-fold (0.08 log units) above the measured number, and the stated range covers the measured number.
By their numbers in this assay, from the lowest: compounds 2, 3 and 1 (each within the scatter of the next).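

Compound 2 and compound 3 give the first direct test of ring size at this place: putting cyclohexyl in place of cyclopropyl on a triple-bonded carbon gives a 1.5-fold higher number from compound 2 to compound 3 (0.16 log units; within the scatter) in this assay and so shows no change that can be told from the scatter. Cyclohexyl in place of 1,3-thiazol-2-yl gives a 1.3-fold lower number from compound 1 to compound 3 (0.10 log units; within the scatter) as well, so the three groups shown on this carbon all lie within the scatter of one another, and neither the size nor the kind of ring separates these compounds. No measurement at hand explains why such different rings give such similar numbers.

As far as these compounds go, all three groups are single rings, so it remains open whether the number would stay in this range with an amine or a carboxylic acid on the ring, or with a straight hexyl chain in place of a ring. How these compounds behave at other adenosine receptors also cannot be told from these numbers.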